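From cyclopropylamino to pyrrolidin-1-yl on the shared core

This account rests on a few compounds, and the source may have more. Where it says the series, first, only, none or still open, it means among the compounds named here.

In an ADME assay on Akata cells (Homo sapiens) for cytotoxicity, with a stated time of 7 days (a lower number here means that less compound is tolerated, a higher number that more compound is tolerated), compound 1 `CCCCCCCCOc1nc(N)nc2c1ncn2/C=C1/CC1(CO)CO` gives only a limit of > 20000 nM and no number. Compound 2 `Nc1nc(NC2CC2)c2ncn(/C=C3/CC3(CO)CO)c2n1` likewise gives only a limit of > 20000 nM and no number. Among the measured compounds shown here, the one measured step that the two limits leave unreadable from compound 1 to compound 2 therefore offers no readable size, and the limit of > 20000 nM in this assay, at which 2 of the 2 values shown sit, holds both values. Compound 3 `Nc1nc(N2CCCC2)c2ncn(/C=C3/CC3(CO)CO)c2n1` differs from compound 2 by the change pyrrolidin-1-yl in place of cyclopropylamino on an aromatic carbon on an aromatic carbon. Hence the estimate is a step that the limit leaves unreadable from compound 2 to compound 3 in this assay and no step beyond the scatter is expected. For compound 3 the expected value is 25000 nM with an estimated range from 10000 nM to 60000 nM and possibly only a limit.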

Compound 3, half-maximal cytotoxic concentration: > 24000 nM
Compound 3 was reported as a limit; the forecaster's own chance of this, stated with the estimate: 80%; the middle value lies beyond the limit too.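

Among the compounds shown here, compound 1, compound 2 and compound 3 are all reported only as limits in this assay, so no step among them can be read. The compounds shown leave open at what concentration any of them reaches half-maximal cytotoxicity.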